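Ring Enlargement on the Carbonyl Carbon: Compound 2 to Compound 3

A few compounds are considered here, and "the series" means these few. Any claim that something is new, unique, unknown or untested is made for them only; others in the source may bear on it.

Compound 2 `CC1(C)SC(c2ccccc2N)=NN1C(=O)C1CCC1` stands highest of the two compounds measured in an assay on isolated protein for inhibition of Nitric oxide synthase, inducible (Homo sapiens), read by scintillation counting, with a stated time of 30 min, tested at 50 uM; a lower number here means less inhibition, a higher number more inhibition at the concentration tested (going by the name of the read-out): compound 2 gives 46.9%, whereas compound 1 `CCC(=O)N1N=C(c2ccccc2N)SC1(C)C` gives 19.2%. Among the measured compounds shown here, the only measured step, a number 27.7 percentage points higher from compound 1 to compound 2 (beyond the scatter), went with cyclobutyl in place of ethyl on the carbonyl carbon.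

Compound 3 `CC1(C)SC(c2ccccc2N)=NN1C(=O)C1CCCC1` differs from compound 2 by cyclopentyl in place of cyclobutyl on a carbonyl carbon. For the measured compounds named here, the single measured step bears on this change only loosely: both alter the group on the carbonyl carbon, and the measured one raised the reading by a modest amount. Whether going from a four-membered ring to a five-membered ring continues in the same direction cannot be read from one step; the direction is taken as upward, but a smaller step than the measured one is expected, and a step within the scatter is possible. Compound 3 is therefore expected to give 55% in this assay, with a range from 35% to 75%. The expected step from compound 2 is a number 8.1 percentage points higher from compound 2 to compound 3 (within the scatter), lying at the edge of the scatter.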

Compound 3, a percentage reported as inhibition, at one concentration (the size of the read-out at that concentration, not a potency): 42.2%
Estimate against measurement, compound 3: 12.8 percentage points above; the measured number falls inside the stated range.
By their numbers in this assay, from the lowest: compound 1; then compounds 3 and 2 (each within the scatter of the next).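

In this assay the ring enlargement on the carbonyl carbon reads as a number 4.7 percentage points lower from compound 2 to compound 3 (within the scatter) and so separates cyclobutyl from cyclopentyl at this position by no more than repeated measurements would; the earlier pair could not show this. Cyclopentyl also gives a number 23 percentage points higher from compound 1 to compound 3 (beyond the scatter) and so stands clear of ethyl much as cyclobutyl does, which means that among these compounds both rings read above the ethyl amide while showing no trend with ring size. No available measurement accounts for these readings.

Still open, as far as these compounds go, is whether the level seen with the two rings holds for a larger ring such as cyclohexyl, an aromatic ring such as phenyl, a branched chain such as isopropyl, or a basic group such as an aminomethyl on the carbonyl carbon. The readings are also at a single concentration and the rest of the core is common to compound 1, compound 2 and compound 3, so they give no potency and say nothing about changes elsewhere on the core.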